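Swapping a saturated ring for an aromatic one on the anilide nitrogen

The source may report more compounds than this note shows. Statements on the series, on what has been measured and on what is new or still open speak of the compounds shown alone.

Measured so far:
compound 1 `Cc1ccc(Nc2cc(-c3ccccc3)oc(=O)c2)cc1` gives 0.059 uM
compound 2 `O=c1cc(NC2CCCCC2)cc(-c2ccccc2)o1` gives 9.15 uM

In a functional assay on KBVIN cells (Homo sapiens) for cytotoxicity, read by MTT assay, with a stated time of 72 h (a lower number here means that less compound is needed, a higher number that more compound is needed for the effect), compound 2 stands as the higher of the two numbers. Among the compounds with values here, the one step on record, a 160-fold higher number from compound 1 to compound 2 (2.19 log units; beyond the scatter), shows that this change lifted the number sharply. Compound 3 `O=c1cc(Nc2ccc(Br)cc2)cc(-c2ccccc2)o1` differs from compound 2 by 4-bromophenyl in place of cyclohexyl on a nitrogen on an aromatic ring. That puts an aromatic ring back on the nitrogen, so the step is expected to run the other way and to be large: a 92-fold lower number from compound 2 to compound 3 (1.96 log units; beyond the scatter). Compound 3 is therefore estimated at 0.1 uM, with a range from 0.03 uM to 0.5 uM.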

Compound 3, concentration for half-maximal effect: 0.24 uM
For compound 3 the middle estimate is 2.4-fold (0.38 log units) below the measured one; measured number inside the range.
By their numbers in this assay, from the lowest: compound 1; then compound 3; then compound 2.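

In this assay, an aromatic ring on the nitrogen pays off for a second time: 4-bromophenyl in place of cyclohexyl gives a 38-fold lower number from compound 2 to compound 3 (1.58 log units; beyond the scatter), so the low number is not tied to 4-methylphenyl alone. What sits on that aromatic ring also matters, though less: bromo in place of methyl gives a 4.1-fold higher number from compound 1 to compound 3 (0.61 log units; beyond the scatter), a modest step but beyond the scatter. From the compounds shown here alone, whether a methoxy group or an amine on that ring would match methyl stays open. Nothing at hand explains either step.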